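A few compounds are considered here, and "the series" means these few. Any claim that something is new, unique, unknown or untested is made for them only; others in the source may bear on it.

Measured compounds:
- compound 1, `CCc1cccc(NC(=O)N[C@H](C)c2ccccc2)c1`: 36%
- compound 2, `COc1cccc(NC(=O)N[C@H](C)c2ccccc2)c1`: 70%

Both were tested in an ADME assay on the whole organism with Oryza sativa as the target, tested at 10 uM; on this read-out lower numbers stand for a stronger effect and higher numbers for a weaker effect at the one concentration tested. Compound 2 stands highest of the two numbers; its nearest neighbour is compound 1, and the step of a number 34 percentage points higher from compound 1 to compound 2 (beyond the scatter) places compound 2 well beyond the scatter above compound 1.

Compound 3, `C[C@@H](NC(=O)Nc1cccc(Cl)c1)c1ccccc1`, has not yet been measured in this assay. It differs from compound 2 in one place: chloro in place of methoxy on an aromatic carbon.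

Among the compounds with values here, the only measured step, a number 34 percentage points higher from compound 1 to compound 2 (beyond the scatter), concerns a different replacement at the same aromatic carbon and so bears on the new step only loosely: it shows that a change at this position can move the read-out by a large amount. Nothing measured tells which way a chloro at this position falls relative to methoxy. The working expectation is a value for compound 3 between the two measured numbers, estimated as a step of a number 18 percentage points lower from compound 2 to compound 3 (beyond the scatter) downward from compound 2, though a result within the scatter of compound 2 cannot be excluded. Compound 3 is therefore estimated at 52%, with a range from 30% to 74%.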

Compound 3, a percentage reported as activity, at one concentration (the size of the read-out at that concentration, not a potency): 83%
The estimate for compound 3 lay 31 percentage points below the measured number, outside the stated range (above it).
By their numbers in this assay, from the lowest: compound 1; then compound 2; then compound 3.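

In this assay, chloro on this aromatic carbon, meta to a large group, gives the highest number of the three, with a number 13 percentage points higher from compound 2 to compound 3 (beyond the scatter) and a number 47 percentage points higher from compound 1 to compound 3 (beyond the scatter), so the weakest effect at the one concentration tested now belongs to compound 3. The earlier pair showed only that this place can respond strongly to a change of group; the series now shows three groups separated beyond the scatter, in the order ethyl, methoxy, chloro from the lowest number, and the step from methoxy to chloro, which removes a hydrogen-bond acceptor and one heavy atom, moves the number further from compound 1 rather than back towards it. No measurement in hand accounts for this order.

Still open, from the compounds shown here alone, is whether the low number of compound 1 is particular to ethyl or carries over to a longer chain such as propyl, and where an amine or a carboxylic acid on the same carbon would fall. The three compounds also leave untested whether this order of ethyl, methoxy and chloro holds for the same groups elsewhere on the ring or with the other stereoisomer of the shared core.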